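The source may report more compounds than this note shows. Statements on the series, on what has been measured and on what is new or still open speak of the compounds shown alone.

Measured so far in an ADME assay on THP-1 cells (Homo sapiens) for cytotoxicity, read by resazurin assay, with a stated time of 72 h; a higher number here means that more compound is tolerated, a lower number that less compound is tolerated:
Compound 1 `CC(C)(C)c1ccc(C(=O)/C=C/c2ccc([N+](=O)[O-])o2)cc1` gives only a limit of the assay, > 50000 nM.
Compound 2 `O=C(/C=C/c1ccc([N+](=O)[O-])o1)c1ccc(-n2ccnc2)cc1` gives 22200 nM.
Compound 3 `O=C(/C=C/c1ccc([N+](=O)[O-])o1)c1ccc(-c2ccccc2)cc1` gives 50400 nM.

Compound 3 holds the higher of the two numbers; the other number belongs to compound 2, and the two are separated by the step of a 2.3-fold higher number from compound 2 to compound 3 (0.36 log units; beyond the scatter). The third value is a limit. Compound 4 `CCCCc1ccc(C(=O)/C=C/c2ccc([N+](=O)[O-])o2)cc1` differs from compound 3 by butyl in place of phenyl on an aromatic carbon. Going by the values given here, two measured steps bear on this change: a 2.3-fold higher number from compound 2 to compound 3 (0.36 log units; beyond the scatter), and a step that the limit leaves unreadable from compound 1 to compound 3, whose size stays hidden by the limit (the limit of > 50000 nM in this assay, at which 1 of the 3 values shown sits). Compound 1 also carries a saturated alkyl group, tert-butyl, and sits at the limit (the limit of > 50000 nM in this assay, at which 1 of the 3 values shown sits), so compound 4 is expected to be tolerated about as well as compound 3, with a 1.0-fold lower number from compound 3 to compound 4 (0.00 log units; within the scatter) expected to stay within the scatter. The estimate for compound 4 is 50000 nM, expected between 25000 nM and 100000 nM.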

Compound 4, half-maximal cytotoxic concentration: 48700 nM
Compound 4: the middle estimate sits 1.0-fold (0.01 log units) above what was measured, within the range that was stated.
By their numbers in this assay, from the lowest: compound 2; then compounds 4 and 3 (each within the scatter of the next).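

In this assay, the two groups on an aromatic carbon para to a large group cannot be told apart, with a 1.0-fold lower number from compound 3 to compound 4 (0.01 log units; within the scatter), so butyl, which has no ring, stands level with phenyl. Among the groups with a readable step at this position, 1H-imidazol-1-yl remains the one set apart, with a 2.2-fold higher number from compound 2 to compound 4 (0.34 log units; beyond the scatter). The last step gives only a floor, an at least 1.0-fold lower number from compound 1 to compound 4 (0.01 log units; that floor lies within the scatter), and compound 1 holds a limit of the assay: the limit of > 50000 nM in this assay, at which 1 of the 4 values shown sits.

Going by these compounds, it remains open whether an amine or a carboxylic acid here would fall with compound 2 or with compounds 3 and 4. On these data alone, it also remains open whether a longer chain than butyl would stay level with compound 4.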